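A few compounds are considered here, and "the series" means these few. Any claim that something is new, unique, unknown or untested is made for them only; others in the source may bear on it.

Working notes on the series.

Compound 1 `CCCCCCCC/C=C\CCCCCCC(=O)c1ncc(-c2ccco2)o1` is the reference point here. In an assay on isolated protein for inhibition of Fatty-acid amide hydrolase 1 (Homo sapiens) (a higher number here means a weaker inhibitor, a lower number a stronger inhibitor), compound 1 gives 54 nM, the second highest of the three numbers in hand. Among the measured compounds shown here, the only number above it belongs to compound 3 `CCCCCCCCCC(=O)C(F)(F)F`, which in this assay gives 130 nM; the gap between the two lies beyond the usual scatter. The lowest number belongs to compound 2 `CCCCCCCC/C=C\CCCCCCC(=O)c1nc2ncccc2o1`, which in this assay gives 2.3 nM, far below compound 1 and well beyond the scatter. No two of these three differ in only one place, so no single-point step can be read off from them, and the numbers for compounds 2 and 3 serve only to frame where compound 1 sits.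

Compound 4 `CCCCCCCC/C=C\CCCCCCC(=O)c1ncc(-c2cccnc2)o1` has not yet been measured in this assay. It differs from compound 1 in one place: pyridin-3-yl in place of furan-2-yl on an aromatic carbon. The shared core of compound 1 and its long unsaturated chain are kept unchanged. For the measured compounds named here, with no measured pair of this kind to lean on, the expected step of a 2.5-fold lower number from compound 1 to compound 4 (0.39 log units; beyond the scatter) from compound 1 to compound 4 is a modest move toward a lower number, close to the edge of the scatter. Compound 4 is therefore estimated at 22 nM in this assay, with a range from 6 nM to 70 nM.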

Compound 4, inhibition constant: 61 nM
Estimate against measurement, compound 4: 2.8-fold (0.44 log units) below; measured number inside the range.
By their numbers in this assay, from the lowest: compound 2; then compounds 1 and 4 (each within the scatter of the next); then compound 3.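

In this assay the step of a 1.1-fold higher number from compound 1 to compound 4 (0.05 log units; within the scatter) shows that this aromatic carbon, next to the ring oxygen of the shared core, accepts pyridin-3-yl in place of furan-2-yl with no readable difference. A six-membered aromatic ring carrying a ring nitrogen and a five-membered aromatic ring carrying a ring oxygen therefore read alike at this position, so the exchange of ring size and hetero atom leaves no mark on this measurement, at least for this one pair. The compounds in hand offer no measurement that would explain why the two groups read alike.

Still open, on these data alone, is whether the position stays this permissive for groups of another kind: a plain phenyl ring with no hetero atom, the isomeric pyridin-2-yl and pyridin-4-yl rings, a pyridine ring bearing a carboxylic acid or a methyl ester, or a small methyl group in place of any ring. Also open, as far as these compounds go, is whether pyridin-3-yl and furan-2-yl would still read alike on the same core with a saturated chain or a shorter chain in place of the long unsaturated one.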